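A Hydroxyl Enters the Core of Compound 2

The source may hold more compounds than are shown below. What is called first, only, known or untested is meant among the compounds shown, and "the series" means these compounds.

Of the compounds shown here, three of a shared core have been measured: compound 1 `CCn1c(CNc2ccccc2)nnc1SCC(=O)Nc1ccc(C(=O)OC)cc1`, compound 2 `CCc1ccc2oc(CSc3nnc(CNc4ccccc4)n3CC)nc2c1` and compound 3 `CCC(=O)c1ccc2nc(CSc3nnc(CNc4ccccc4)n3CC)oc2c1`. In an assay on isolated protein for inhibition of long-chain fatty acid transport protein 1 (Homo sapiens) (a higher number here means a weaker inhibitor, a lower number a stronger inhibitor), compound 1 gives 540 nM. Compound 3 gives 900 nM in this assay. Compound 2 stands at the limit of > 1000 nM in this assay, at which 1 of the 3 values shown sits, which is a limit of the measurement and not a number. In this assay compound 2 is recorded as > 1000 nM.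

Compound 4 `CCC(O)c1ccc2oc(CSc3nnc(CNc4ccccc4)n3CC)nc2c1` is not yet measured. It differs from compound 2 in one place: 1-hydroxypropyl in place of ethyl on an aromatic carbon. Within the data shown here, no measured pair shows this change directly, so its size is unknown. Compound 3 carries a carbonyl at the same place and gives 900 nM, a measured number. Compound 2, by contrast, stands at a limit. On that basis a small gain, if any, is expected for compound 4, a step of a number no higher from compound 2 to compound 4 (the limit leaves the size open) from a limit toward a measurable number. Compound 4 is therefore estimated at 1000 nM, with a range from 400 nM to 3000 nM in this assay.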

Compound 4, half-maximal inhibitory concentration: > 1000 nM
Compound 4 ended at the assay's limit; the forecaster's own chance of this, stated with the estimate: 40%; the middle value sits exactly at the limit.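

Compound 2 and compound 4 both stand at a limit of the measurement in this assay, so the step between them cannot be read: the limit of > 1000 nM in this assay, at which 2 of the 4 values shown sit.

The compounds shown leave open whether 1-hydroxypropyl in place of ethyl on an aromatic carbon changes the inhibition at all.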